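Swapping Dimethylamino for Nitro: What to Expect

The source may hold more compounds than are shown below. What is called first, only, known or untested is meant among the compounds shown, and "the series" means these compounds.

Two compounds from this study share a common core and have been tested in a functional assay on the whole organism (strain Swiss albino) with Mus musculus as the target, with a stated time of 4 h; on this read-out lower numbers stand for an effect already at smaller amounts and higher numbers for an effect only at larger amounts of compound. Compound 1 `C/C(=N\NC(=O)Nc1cccc2ccccc12)c1ccc(Cl)cc1Cl` gives 300 mg/kg in this assay. Compound 2 `CN(C)c1ccc(/C=N/NC(=O)Nc2cccc3ccccc23)cc1` gives 300 mg/kg in this assay. Compound 2 therefore stands level with compound 1 at the digits shown; the two readings lie within the scatter of each other, so neither can be called stronger or weaker than the other.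

Compound 3 `O=C(N/N=C/c1ccc([N+](=O)[O-])cc1)Nc1cccc2ccccc12` has not yet been measured. It differs from compound 2 in a single place: nitro in place of dimethylamino on an aromatic carbon. Among the measured compounds shown here, no step between measured compounds covers this kind of exchange, so the data give nothing that points in one direction. For the measured compounds named here, the only guide is that compound 1 and compound 2, although they differ in several ways, return the same reading in this assay. On that basis the step from compound 2 to compound 3 is expected to stay within the scatter, as no change at the digits printed from compound 2 to compound 3 (within the scatter). Compound 3 is expected to give 300 mg/kg in this assay, with a range from 150 mg/kg to 600 mg/kg.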

Compound 3, minimum effective dose: 300 mg/kg
For compound 3 middle estimate and measured number coincide at the digits printed; the measured number falls inside the stated range.
By their numbers in this assay, from the lowest: compounds 1, 2 and 3 (each within the scatter of the next).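

On an aromatic carbon para to a large group, putting nitro in place of dimethylamino gives, in this assay, no change at the digits printed from compound 2 to compound 3 (within the scatter). Among the compounds shown here, this is the first direct comparison between measured compounds that differ in one place, and it concerns two groups of equal heavy-atom count but different make-up: dimethylamino holds carbon and nitrogen, while nitro holds nitrogen and oxygen. No accompanying measurement explains this result, so it stands as an observation without a known cause.

A single exchange at this position cannot show how other groups would read there, so a carboxylic acid, a primary amine or a longer alkyl chain in the same place remains an open case. Going by these compounds, it is also open whether nitro and dimethylamino would read alike on another core, such as the core of compound 1, which carries two chlorine atoms on its aromatic ring and a methyl group on the carbon of its carbon-nitrogen double bond.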